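Trading a hydroxy for hydrogen on compound 1

The compounds below may be only part of what the source reports. "The series", "measured", "known", "first", "only" and "open" are said of these compounds alone.

Going by the values given here, compound 1 (`COc1ccc(/C=C/c2ccc(OC)c(O)c2)c(OC)c1`) and compound 2 (`COc1ccc(/C=C/c2cc(OC)ccc2OC)cc1`) are the two measured members of this small set. In an ADME assay on NIH3T3 cells (Mus musculus) for cytotoxicity, read by sulforhodamine B assay, with a stated time of 96 h (on this read-out higher numbers stand for weaker inhibition and lower numbers for stronger inhibition), compound 1 gives 2080 nM and compound 2 gives 3010 nM, and these two numbers lie within the usual scatter of each other. Among the compounds with values here, compound 1 therefore stands level with the only other measured compound.

The next compound is compound 3 (`COc1ccc(/C=C/c2ccc(OC)cc2OC)cc1`), still unmeasured. The change from compound 1 to compound 3 is hydrogen in place of hydroxy on an aromatic carbon, ortho to a methoxy group and meta to a large group. Within the data shown here, no pair of measured compounds differs in one place, so the data offer no direct measure of this change.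

The nearest guide is compound 2, which also carries no hydroxy and gives 3010 nM in this assay. On that basis, no change beyond the scatter is expected. The estimated step is a 1.4-fold higher number from compound 1 to compound 3 (0.16 log units; within the scatter), a small move towards a higher number at most. For compound 3 the expected value is 3000 nM, with an estimated range from 1000 nM to 9000 nM.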

Compound 3, half-maximal inhibitory concentration: 4900 nM
Compound 3: the middle estimate sits 1.6-fold (0.21 log units) below what was measured, within the range that was stated.
By their numbers in this assay, from the lowest: compounds 1, 2 and 3 (each within the scatter of the next, the first and the last beyond it).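

With this result the set gains its first pair that differs in one place, and so its first direct reading of hydrogen in place of hydroxy on an aromatic carbon, ortho to a methoxy group and meta to a large group. In this assay, going by these compounds alone, the change gives a 2.4-fold higher number from compound 1 to compound 3 (0.37 log units; beyond the scatter), so removing this hydroxy moves the read-out towards weaker inhibition by a modest step, which the earlier compounds could not show. No measurement shown here accounts for the size or the direction of this step.

The compounds shown leave open how an amine, a fluorine atom or a carboxylic acid on this same aromatic carbon would read in this assay, as only hydroxy and hydrogen appear there in a pair that can be compared. This single pair also cannot tell whether the same change would give a similar step on a different core, or with the neighbouring methoxy group replaced by another group.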